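Swapping One Aromatic Ring on a Shared Core

The source may hold more compounds than are shown below. What is called first, only, known or untested is meant among the compounds shown, and "the series" means these compounds.

Compound 1 `O=C(N/N=C/c1ccc(O)cc1)c1ccc(-c2ccc(F)cc2)o1` and compound 2 `Cc1cccc(/C=N/NC(=O)c2ccc(-c3ccccc3[N+](=O)[O-])o2)c1` share a common core and were both tested in a functional assay on HL-60 cells (Homo sapiens) for inhibition, read by MTT assay, with a stated time of 48 h, tested at 10 uM; a lower number here means less inhibition of growth, a higher number more inhibition of growth at the concentration tested. In this assay compound 1 gives 1.07%, the lowest of the two numbers, while compound 2 gives 9.54%; the gap between them lies within the usual scatter, so neither can be said to inhibit growth more than the other. Compound 3 `O=C(N/N=C/c1ccccc1Cl)c1ccc(-c2ccc(F)cc2)o1` has not yet been measured. It differs from compound 1 in one place: 2-chlorophenyl in place of 4-hydroxyphenyl on a carbon with a double bond to nitrogen. Among the measured compounds shown here, no step between measured compounds shows what such a change does, so the expectation rests on compound 1 alone, whose value of 1.07% sits close to no inhibition at all. Only a small rise, not beyond the scatter, is expected a number 6.9 percentage points higher from compound 1 to compound 3 (within the scatter) in this assay. The estimate for compound 3 is 8%, with a range from -5% to 25%.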

Compound 3, percent growth inhibition at one concentration: -3.22%
Compound 3: the middle estimate sits 11.2 percentage points above what was measured, and the stated range covers the measured number.
By their numbers in this assay, from the lowest: compounds 3, 1 and 2 (each within the scatter of the next, the first and the last beyond it).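

Among the compounds shown here, this is the first step that reads the position directly: with 2-chlorophenyl in place of 4-hydroxyphenyl on a carbon with a double bond to nitrogen, this assay shows a number 4.3 percentage points lower from compound 1 to compound 3 (within the scatter). The group that enters has no hydrogen-bond donors or acceptors, while the group that leaves has one of each, yet this exchange does not move the number beyond the scatter, and both compounds remain close to no inhibition of growth. Nothing available explains this outcome.

From the compounds shown here alone, whether an amine or a carboxylic acid on this carbon would give a number beyond the scatter from compound 1 remains open. Also open, going by these compounds, is whether a longer chain there would do so, since both groups compared here are single aromatic rings.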